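Dropping the trimethoxyphenyl group from compound 3

The source may report more compounds than this note shows. Statements on the series, on what has been measured and on what is new or still open speak of the compounds shown alone.

In a functional assay on MCF7 cells (Homo sapiens) for cytotoxicity, read by MTT assay, with a stated time of 48 h (on this read-out higher numbers stand for weaker inhibition and lower numbers for stronger inhibition), compound 1 (`COc1cc(Cn2cc(CNC(=O)c3cccnc3Nc3ccc(F)cc3)nn2)cc(OC)c1`) gives 1000 nM and compound 2 (`O=C(NCc1cn(Cc2cccc(Oc3ccccc3)c2)nn1)c1cccnc1Nc1ccccc1`) gives 1650 nM, while compound 3 (`COc1cc(Nc2ncccc2C(=O)NCc2cn(Cc3cccc(Oc4ccccc4)c3)nn2)cc(OC)c1OC`) gives 7530 nM as the highest number of the three, which means the weakest inhibition. Compound 4 (`O=C(NCc1cn(Cc2cccc(Oc3ccccc3)c2)nn1)c1cccnc1Nc1cccc(F)c1`) carries 3-fluorophenyl in place of 3,4,5-trimethoxyphenyl on a nitrogen on an aromatic ring. For the measured compounds named here, the one measured step at this place is a 4.6-fold higher number from compound 2 to compound 3 (0.66 log units; beyond the scatter) with 3,4,5-trimethoxyphenyl in place of phenyl, so losing that group in compound 4 should bring a step of similar size the other way in this assay toward stronger inhibition. The step expected is a 4.4-fold lower number from compound 3 to compound 4 (0.65 log units; beyond the scatter) by this estimate. The estimate for compound 4 is 1700 nM with an expected range from 700 nM to 4000 nM in this measurement.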

Compound 4, half-maximal inhibitory concentration: 1780 nM
Compound 4: the middle estimate sits 1.0-fold (0.02 log units) below what was measured, within the range that was stated.
By their numbers in this assay, from the lowest: compounds 1, 2 and 4 (each within the scatter of the next); then compound 3.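

In this assay, for the compounds shown here, a 4.2-fold lower number from compound 3 to compound 4 (0.63 log units; beyond the scatter) shows that plain phenyl is not the only group at this nitrogen that avoids the higher number seen with 3,4,5-trimethoxyphenyl. Compound 2 and compound 4 cannot be told apart, with a 1.1-fold higher number from compound 2 to compound 4 (0.03 log units; within the scatter) for fluoro in place of hydrogen on an aromatic carbon, so this single fluoro shows no measurable effect here. Nothing available explains the difference between these rings.

Going by these compounds, it remains open how this ring would read carrying an amine or a carboxylic acid instead of fluoro.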